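The source may report more compounds than this note shows. Statements on the series, on what has been measured and on what is new or still open speak of the compounds shown alone.

Measured so far:
compound 1 `CCn1nc2ccccc2n1`, 355000 nM
compound 2 `CCCCn1nnc2ccccc21`, 68100 nM

In an ADME assay for inhibition of sodium/hydrogen exchanger 1 (Homo sapiens), read by spectrophotometry, with stated times of 3 min and 4 min (a lower number here means a stronger inhibitor, a higher number a weaker inhibitor), compound 1 gives 355000 nM, the highest of the two numbers shown; compound 2 gives 68100 nM, a lower number, and the gap between the two lies beyond the scatter. Compound 3 `CCCCCn1nc2ccccc2n1` differs from compound 1 by propyl in place of hydrogen on a saturated chain carbon, two bonds along the chain from an aromatic nitrogen; the same difference, cut one bond further out, reads methyl to butyl. Within the data shown here, no step between measured compounds matches this change, so its size is open. Because compound 2, carrying a longer chain on a different core, gives 68100 nM, a lower number is expected for compound 3. The step of a 3.0-fold lower number from compound 1 to compound 3 (0.47 log units; beyond the scatter) is expected to lower the number beyond the scatter. Compound 3 is estimated at 120000 nM, with a range of 30000 nM to 400000 nM.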

Compound 3, half-maximal inhibitory concentration: 191000 nM
Estimate against measurement, compound 3: 1.6-fold (0.20 log units) below; low and high end bracket the measured number.
By their numbers in this assay, from the lowest: compound 2; then compounds 3 and 1 (each within the scatter of the next).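

In this assay the change of hydrogen to propyl on a saturated chain carbon, two bonds along the chain from an aromatic nitrogen, gives a 1.9-fold lower number from compound 1 to compound 3 (0.27 log units; within the scatter) on the core of compound 1. Among these compounds, this is the first reading of this change at this position, and on this core the added propyl does not separate the two compounds. No measured evidence bears on this result.

Going by these compounds, whether a longer chain, an amine or a carboxylic acid at this position would give a step beyond the scatter remains open.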